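Swapping cyclohexyl for benzyl on a fused imidazole nitrogen

The source may report more compounds than this note shows. Statements on the series, on what has been measured and on what is new or still open speak of the compounds shown alone.

Measured compounds:
- Compound 1, `FC(F)(F)c1cccc(-c2cn3ccnc3c(-c3ccc4ncn(C5CCCCC5)c4c3)n2)c1`: 0.3%
- Compound 2, `O=Cc1ccc(-c2cn3ccnc3c(-c3ccc4ncn(Cc5ccccc5)c4c3)n2)cc1`: 11.6%
- Compound 3, `c1cn2cc(-c3ccc4c(c3)ncn4C3CCCCC3)nc(-c3ccc4ncn(C5CCCCC5)c4c3)c2n1`: 5.48%

All three were tested in a functional assay on ACHN cells (Homo sapiens) for inhibition, read by sulforhodamine B assay, with a stated time of 48 h, tested at 10 uM; a higher number here means more inhibition at the concentration tested (going by the name of the read-out), a lower number less inhibition. Compound 3 gives 5.48%, and its gaps to compound 1 and to compound 2 both fall within the usual scatter of this assay, so the three numbers cannot be told apart with confidence.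

Compound 4, `c1ccc(Cn2cnc3ccc(-c4nc(-c5ccc6c(c5)ncn6C5CCCCC5)cn5ccnc45)cc32)cc1`, has not yet been measured. It differs from compound 3 in one place: benzyl in place of cyclohexyl on an aromatic nitrogen. Among the compounds with values here, no measured pair shows this exact change on its own. Compound 2 carries a benzyl group and compound 1 a cyclohexyl group, yet their numbers sit within the scatter of each other, so no step beyond the scatter is expected here. The estimate for the change from compound 3 to compound 4 is a number 1.5 percentage points higher from compound 3 to compound 4 (within the scatter). Compound 4 is therefore expected to give about 7%, with a likely range from -5% to 20%.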

Compound 4, a percentage reported as inhibition, at one concentration (the size of the read-out at that concentration, not a potency): 80.1%
Compound 4: the middle estimate sits 73.1 percentage points below what was measured; the measured number lies above the stated range.
By their numbers in this assay, from the lowest: compounds 1, 3 and 2 (each within the scatter of the next, the first and the last beyond it); then compound 4.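

In this assay, within the data shown here, benzyl in place of cyclohexyl on this aromatic nitrogen gives a number 74.6 percentage points higher from compound 3 to compound 4 (beyond the scatter) and is the only single-place change that can be read so far. It shows that this one substituent can decide whether the compound registers at the concentration tested, which compound 1 and compound 2, differing in more than one place, could not show. No measurement available here explains the size of this step.

The compounds shown leave open whether phenethyl, a longer chain, or a benzyl ring carrying an amine would keep this inhibition on the same nitrogen. Also open, from the compounds shown here alone, is what benzyl would do in place of the remaining cyclohexyl of compound 4.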